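Trifluoromethyl in place of ethyl: Vero cell cytotoxicity

This account rests on a few compounds, and the source may have more. Where it says the series, first, only, none or still open, it means among the compounds named here.

Measured compounds:
- compound 1, `Cc1nn2cccc(C)c2c1C(=O)NCc1ccc(N2CCC(c3ccc(OC(F)(F)F)cc3)CC2)cc1`: "not determined" (no result reported)
- compound 2, `Cc1nn2c(C)cccc2c1C(=O)NCc1ccc(N2CCC(c3ccc(OC(F)(F)F)cc3)CC2)cc1`: "not determined" (no result reported)
- compound 3, `CCc1ccn2nc(C)c(C(=O)NCc3ccc(N4CCC(c5ccc(OC(F)(F)F)cc5)CC4)cc3)c2c1`: > 100000 nM

In an ADME assay on Vero cells (Chlorocebus sabaeus) for cytotoxicity, read by CCK-8 assay, with a stated time of 72 h (on this read-out higher numbers stand for weaker inhibition and lower numbers for stronger inhibition), compound 1 gives "not determined" (no result reported) and compound 2 gives "not determined" (no result reported), so neither carries a number. Compound 3 gives > 100000 nM in this assay, which is a limit of the assay and not a number. Compound 3 therefore stands at the upper boundary of what this assay reports, as told by the limit of > 100000 nM in this assay, at which 1 of the 3 values shown sits.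

Compound 4, `Cc1nn2ccc(C(F)(F)F)cc2c1C(=O)NCc1ccc(N2CCC(c3ccc(OC(F)(F)F)cc3)CC2)cc1`, is the compound still to be measured. It differs from compound 3 by trifluoromethyl in place of ethyl on an aromatic carbon, on a six-membered aromatic ring with one nitrogen that is part of a fused system of two rings. Among the compounds with values here, no measured step of this kind is available to compare against. Compound 3 sits at a limit, and there is no basis for expecting the step from compound 3 to compound 4 to move beyond the usual scatter. Compound 4 is therefore estimated at 100000 nM, with a range from 30000 nM to 300000 nM, and the step of a number no higher from compound 3 to compound 4 (the limit leaves the size open) is expected to be nil; it is also expected that this assay may again report only a limit for compound 4.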

Compound 4, half-maximal inhibitory concentration: > 100000 nM
Compound 4 ended at the assay's limit (the forecaster's own chance of this, stated with the estimate: 75%); the middle value lies on the limit itself.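

In this assay, compound 3 and compound 4 both end at a limit and not at a number, so the step between them cannot be read: the limit of > 100000 nM in this assay, at which 2 of the 4 values shown sit.

The compounds shown leave open how far either compound lies from that limit, and whether trifluoromethyl in place of ethyl on an aromatic carbon changes the read-out at all.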